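Lengthening the acid chain of compound 2

This account rests on a few compounds, and the source may have more. Where it says the series, first, only, none or still open, it means among the compounds named here.

In an ADME assay on microsomes (Rattus norvegicus) for metabolic stability, using NADPH (a higher number here means that the compound lasts longer, a lower number that the compound disappears faster), compound 1 (`COc1cc([C@@H](O)[C@@H](CCCc2ccsc2)Cn2ccc(CCC(=O)O)c2)cc(OC)c1C`) gives < 0.25 h as a limit of the assay, not a number. Compound 2 (`COc1cc([C@@H](O)[C@@H](CCCc2cccs2)Cn2ccc(CC(=O)O)c2)cc(OC)c1C`) gives < 0.25 h as a limit too, not a number. Compound 2 therefore offers no exact half-life as a starting point, and it shares its place with compound 1 (the limit of < 0.25 h in this assay, at which 2 of the 2 values shown sit).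

Compound 3 (`COc1cc([C@@H](O)[C@@H](CCCc2cccs2)Cn2ccc(CCC(=O)O)c2)cc(OC)c1C`) differs from compound 2 in one place (carboxymethyl in place of carboxy on a saturated chain carbon bound to an aromatic carbon): carboxymethyl in place of carboxy on a saturated chain carbon bound to an aromatic carbon. Among the measured compounds shown here, no measured pair shows what this change does, so no step beyond the usual scatter is expected in this assay for this compound. The estimated step (a step that the limit leaves unreadable from compound 2 to compound 3) stays within that scatter. Compound 3 is expected at 0.2 h (estimated range 0.1 h to 0.5 h), and the assay may report only a limit.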

Compound 3, half-life: < 0.25 h
Compound 3: no number, only a limit; the forecaster's own chance of this, stated with the estimate: 75%; the middle value is on the limit's open side.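

No step can be read from compound 2 or compound 1 to compound 3 in this assay, because all three compounds give a limit and not a number: the limit of < 0.25 h in this assay, at which 3 of the 3 values shown sit.

On these data alone, what carboxymethyl to 2-carboxyethyl, or thiophen-3-yl to thiophen-2-yl, does to the half-life stays open.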